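The compounds below may be only part of what the source reports. "The series", "measured", "known", "first", "only" and "open" are said of these compounds alone.

In a functional assay on Hep 3B2 cells (Homo sapiens) for inhibition, read by sulforhodamine B assay, with a stated time of 72 h (on this read-out lower numbers stand for stronger inhibition and higher numbers for weaker inhibition), compound 1 `C[C@H](Nc1nc(N)nc(N)c1C#N)c1nn(-c2cccc(S(C)(=O)=O)c2)c2cc(F)ccc12` gives 19700 nM and compound 2 `C[C@H](Nc1ncnc2[nH]cnc12)c1nn(-c2ccc(C#N)cc2)c2cc(F)ccc12` gives 13500 nM. These two numbers lie within the usual scatter of each other, so compound 2 stands level with compound 1. Compound 3 `C[C@H](Nc1ncnc2[nH]cnc12)c1nn(-c2cc(F)cc(F)c2)c2cc(F)ccc12` carries 3,5-difluorophenyl in place of 4-cyanophenyl on an aromatic nitrogen. Among the measured compounds shown here, no two measured compounds differ in one place alone, so nothing measured sizes this change, and no shift beyond the scatter is expected in this assay. The expected move is a 1.2-fold lower number from compound 2 to compound 3 (0.09 log units; within the scatter). The estimate for compound 3 is 11000 nM, with an expected range of 4000 nM to 30000 nM.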

Compound 3, half-maximal inhibitory concentration: > 40000 nM
Compound 3 was reported as a limit; the forecaster's own chance of this, stated with the estimate: 15%; middle value at least 3.6-fold (0.56 log units) away from the limit.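

Among the compounds shown here, on an aromatic nitrogen of the shared core, 3,5-difluorophenyl in place of 4-cyanophenyl gives an at least 2.9-fold higher number from compound 2 to compound 3 (0.47 log units; beyond the scatter), the first change here that can be sized in one place. The aryl group at this position therefore matters for inhibition, and this swap weakens it. For compound 3, the reading in this assay is a limit and not a number: the limit of > 40000 nM in this assay, at which 1 of the 3 values shown sits.

On these data alone, the true size of the step remains open, as does whether removing the nitrile or adding the two fluorines drives it. Also open, as far as these compounds go, is how a phenyl ring bearing an amine or a carboxylic acid would behave here.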